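The source may report more compounds than this note shows. Statements on the series, on what has been measured and on what is new or still open speak of the compounds shown alone.

Measured so far:
compound 1, `CCCCC(=O)Nc1ncc(-c2cccc(Cl)c2)c(-c2ccccc2)n1`: 52%
compound 2, `O=C(Nc1ncc(-c2cccc(Cl)c2)c(-c2ccccc2)n1)C1CCCC1`: 47%

Both were run in an assay on CHO cells for displacement of a labelled ligand from adenosine receptor A1 (Homo sapiens), read by scintillation counting, with a stated time of 1 h, tested at 1 uM; a lower number here means less inhibition, a higher number more inhibition at the concentration tested (going by the name of the read-out). Compound 1 gives 52% there, and compound 2 gives 47%. For the measured compounds named here, the step of a number 5 percentage points lower from compound 1 to compound 2 (within the scatter) is the only measured step in the set and lies within the scatter, so the two numbers cannot be ordered. Compound 2 stands with the lower of the two numbers, its nearest neighbour being compound 1, within the scatter.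

Compound 3, `Clc1cccc(-c2cnc(Nc3ccccc3)nc2-c2ccccc2)c1`, is not yet measured. It differs from compound 2 in one place: phenyl in place of cyclopentylcarbonyl on a nitrogen on an aromatic ring. Cut one bond further out, the same change reads as (cyclopentylcarbonyl)amino to anilino. Going by the values given here, the one measured step, a number 5 percentage points lower from compound 1 to compound 2 (within the scatter), concerns only the group on the carbonyl carbon and leaves the carbonyl itself in place; no measured pair shows what happens when cyclopentylcarbonyl leaves and phenyl enters on the ring nitrogen. Among the compounds with values here, no measured step therefore bears directly on this change, and any expectation rests on the two measured compounds alone. The expectation is a step of a number 15 percentage points lower from compound 2 to compound 3 (beyond the scatter) in this assay, taken as downward and beyond the scatter, with wide uncertainty. Compound 3 is estimated at 32%, with a range from 8% to 60%.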

Compound 3, a percentage reported as inhibition, at one concentration (the size of the read-out at that concentration, not a potency): 34%
Compound 3: the middle estimate sits 2 percentage points below what was measured, within the range that was stated.
By their numbers in this assay, from the lowest: compound 3; then compounds 2 and 1 (each within the scatter of the next).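

In this assay, for the compounds shown here, the group on the nitrogen on an aromatic ring is the first place where a change moves the number beyond the scatter: a number 13 percentage points lower from compound 2 to compound 3 (beyond the scatter), and a number 18 percentage points lower from compound 1 to compound 3 (beyond the scatter). The earlier step altered only the group on the carbonyl carbon and stayed within the scatter, whereas here the carbonyl leaves with its substituent and phenyl enters, and both the butylcarbonyl and cyclopentylcarbonyl compounds give a step in the same direction, though inhibition is not abolished, with compound 3 at 34%. No independent measurement on these compounds accounts for the difference.

This single change joins the loss of the carbonyl with the arrival of an aromatic ring, so the compounds shown do not separate the two; a benzoyl group on the same nitrogen, or a cyclopentyl group placed directly on it, would pull them apart. Also open, on these data alone, is how a free amine at this position would read in this assay, and whether a longer chain on the carbonyl would stay within the scatter of compound 1.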